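A few compounds are considered here, and "the series" means these few. Any claim that something is new, unique, unknown or untested is made for them only; others in the source may bear on it.

Measured compounds in this series:

compound 1, `Cc1cccc(OC(=O)c2cc([N+](=O)[O-])cc([N+](=O)[O-])c2)c1`: 500 nM
compound 2, `O=C(Nc1cccc(Br)c1)c1cc([N+](=O)[O-])cc([N+](=O)[O-])c1`: > 50000 nM

Of the compounds shown here, two have been measured in an assay on isolated protein (blood) for inhibition of Polyunsaturated fatty acid 5-lipoxygenase (Homo sapiens), read by ELISA, with stated times of 15 min and 30 min; on this read-out lower numbers stand for stronger inhibition and higher numbers for weaker inhibition. Compound 1, the ester, gives 500 nM. For compound 2, the amide, the assay returns only a limit, > 50000 nM. Compound 2 therefore stands at the limit of this assay, the boundary described as the limit of > 50000 nM in this assay, at which 1 of the 2 values shown sits, at which one of the two values sits. Among the compounds with values here, no step between measured compounds that differ in one place is available, so the ester-to-amide comparison is read only from the two values as they stand.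

Compound 3, `O=C(Nc1cccc(-c2ccccc2)c1)c1cc([N+](=O)[O-])cc([N+](=O)[O-])c1`, is not yet measured in this assay. It differs from compound 2 by phenyl in place of bromo on an aromatic carbon. Nothing measured here says how this exchange acts within the amide series, and the only anchor is the limit for compound 2. The step is expected to be an at least 1.6-fold lower number from compound 2 to compound 3 (0.22 log units; that floor lies within the scatter), with real doubt whether a number rather than a further limit will result. Compound 3 is estimated at 30000 nM, within 5000 nM to 100000 nM.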

Compound 3, half-maximal inhibitory concentration: > 50000 nM
Compound 3: only a limit was reported (the forecaster's own chance of this, stated with the estimate: 55%); middle value at least 1.6-fold (0.22 log units) from the limit.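

Compound 2 and compound 3 both return only a limit in this assay, and no step can be read between them: the limit of > 50000 nM in this assay, at which 2 of the 3 values shown sit.

The compounds shown leave open whether phenyl in place of bromo on an aromatic carbon changes inhibition at all, and whether any amide of this series gives a number rather than a limit.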